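The source may report more compounds than this note shows. Statements on the series, on what has been measured and on what is new or still open speak of the compounds shown alone.

Compound 1 `O=C1CCCN1CCCSc1nc2cc(Cl)ccc2o1`: in an ADME assay on microsomes from liver (Homo sapiens) for metabolic stability, read by LC-MS, using NADPH, with a stated time of 45 min, tested at 0.5 uM (a lower number here means slower removal, a higher number faster removal of the compound), compound 1 gives 4.8 mL/min/g.
Compound 2 `O=C(CCSc1nc2c(Cl)cccc2o1)N1CCCC1`: in this assay compound 2 gives 15.8 mL/min/g.
Compound 3 `CS(=O)(=O)N1CCN(C(=O)CCSc2nc3cc(Cl)ccc3o2)CC1`: in this assay compound 3 gives 0.6 mL/min/g.

Among these three, compound 1 stands second highest. Compound 2 lies above it by a gap that goes beyond the usual scatter, and compound 3 lies below it by a larger gap that also goes beyond the scatter.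

Compound 4 `Clc1ccc2oc(SCCCN3CCCC3)nc2c1` is not yet measured. It differs from compound 1 in a single place: pyrrolidin-1-yl in place of 2-oxopyrrolidin-1-yl on a saturated chain carbon, three bonds along the chain from a sulfur. The shared core, the sulfur and the three-carbon chain stay as they are.

For the measured compounds named here, no step between two measured compounds matches this change, so the expectation rests on the measured values alone. In this assay a step of modest size is expected, in the direction of a higher number, though a result within the scatter of compound 1 cannot be ruled out. The step from compound 1 to compound 4 is estimated at a 1.7-fold higher number from compound 1 to compound 4 (0.22 log units; within the scatter). For compound 4 the expected value is 8 mL/min/g, with a range from 3 mL/min/g to 20 mL/min/g.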

Compound 4, intrinsic clearance in a liver preparation (reported as CLH), per the amount of preparation that the assay uses: 1.9 mL/min/g
Compound 4: middle estimate off by 4.2-fold (0.62 log units), on the high side; the whole stated range lies above it.
By their numbers in this assay, from the lowest: compound 3; then compound 4; then compound 1; then compound 2.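

In this assay the swap of 2-oxopyrrolidin-1-yl for pyrrolidin-1-yl gives a 2.5-fold lower number from compound 1 to compound 4 (0.40 log units; beyond the scatter) at this place on the chain, the first direct comparison there. With the shared core, the sulfur and the three-carbon chain held fixed, losing the ring carbonyl alone moves the number beyond the usual scatter, towards slower removal, so the group at this place does affect the read-out. No measurement shown gives a reason for this fall.

A single step cannot show whether the trend extends to other groups at this place, such as a piperidine ring, a morpholine ring or an open-chain dimethylamine. It also leaves open whether the same swap would move the number the same way on a shorter or longer chain.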